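The compounds below may be only part of what the source reports. "The series", "measured", "known", "first", "only" and "open" are said of these compounds alone.

In a functional assay on MES-SA cells (Homo sapiens) for inhibition, with a stated time of 72 h (on this read-out lower numbers stand for stronger inhibition and higher numbers for weaker inhibition), compound 1 `CCOCc1cc(CN2CCCC2)c(O)c2ncccc12`, which carries ethoxymethyl, gives 8510 nM, and compound 2 `COCc1cc(CN2CCCCC2)c(O)c2ncccc12`, which carries methoxymethyl, gives 9330 nM. Compound 2 therefore stands within the usual scatter of compound 1. Compound 3 `CCOCc1cc(CN2CCCCC2)c(O)c2ncccc12` differs from compound 2 by methyl in place of hydrogen on a saturated chain carbon bound to an oxygen on a saturated carbon, the change of methoxymethyl to ethoxymethyl. Among the measured compounds shown here, no measured pair shows this change alone, so no step beyond the scatter is expected in this assay. The expected size of the step is a 1.1-fold lower number from compound 2 to compound 3 (0.04 log units; within the scatter). The estimate for compound 3 is 8500 nM, with an expected range of 4500 nM to 16000 nM.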

Compound 3, half-maximal inhibitory concentration: 8710 nM
For compound 3 the middle estimate is 1.0-fold (0.01 log units) below the measured one; measured number inside the range.
By their numbers in this assay, from the lowest: compounds 1, 3 and 2 (each within the scatter of the next).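

In this assay, the change of methoxymethyl to ethoxymethyl gives a 1.1-fold lower number from compound 2 to compound 3 (0.03 log units; within the scatter) and so has no readable effect on this piperidin-1-yl compound. Piperidin-1-yl in place of pyrrolidin-1-yl on a saturated chain carbon bound to an aromatic carbon gives a 1.0-fold higher number from compound 1 to compound 3 (0.01 log units; within the scatter) and likewise has no readable effect with ethoxymethyl in place. No measurement is available that would explain either result.

The compounds shown leave open whether a longer chain such as butoxymethyl would give a step beyond the scatter. Going by these compounds, it also remains open whether an aminomethyl group or a carboxylic acid in place of the ether would do so.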